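This account rests on a few compounds, and the source may have more. Where it says the series, first, only, none or still open, it means among the compounds named here.

Series on the shared core of compound 1 `CO[C@H]1C(=O)N2C(C(=O)C(C)(C)C)=C(C)CS(=O)(=O)C12`, which in a physicochemical assay, at pH 7.4 (a lower number here means that the compound disappears faster, a higher number that the compound lasts longer), gives 106 h. Compound 2 `CO[C@H]1C(=O)N2C(C(=O)C(C)(C)C)=C(C)[C@@H](OC=O)S(=O)(=O)C12` reaches only the assay limit, recorded as < 0.5 h (the limit of < 0.5 h in this assay, at which 1 of the 3 values shown sits). Compound 3 `CO[C@H]1C(=O)N2C(C(=O)C(C)(C)C)=C(C)[C@@H](OC(=O)c3ccccc3)S(=O)(=O)C12` gives 24 h in this assay, the lower of the two numbers shown; its nearest neighbour is compound 1, with a 4.4-fold lower number from compound 1 to compound 3 (0.65 log units; beyond the scatter). Changing the acyl group moves the number strongly: an at least 48-fold higher number from compound 2 to compound 3 (1.68 log units; beyond the scatter), whereas an at least 210-fold lower number from compound 1 to compound 2 (2.32 log units; beyond the scatter). Compound 4 `CO[C@H]1C(=O)N2C(C(=O)C(C)(C)C)=C(C)[C@@H](OC(=O)c3ccc(CSc4nc(=O)c(=O)[nH]n4C)cc3)S(=O)(=O)C12` differs from compound 3 by a group of 11 heavy atoms (5 carbon, 3 nitrogen, 2 oxygen, 1 sulfur; one six-membered aromatic ring with 3 hetero atoms) in place of a hydrogen atom, on an aromatic carbon. Within the data shown here, no measured step touches a substituent on the phenyl; both measured changes alter the acyl carbon itself, so in this assay only a small step is expected, no change at the digits printed from compound 3 to compound 4 (within the scatter). Compound 4 is accordingly estimated at 24 h, with a range of 10 h to 60 h.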

Compound 4, half-life: 7.5 h
The estimate for compound 4 lay 3.2-fold (0.51 log units) above the measured number; the measured number lies below the stated range.
By their numbers in this assay, from the lowest: compound 4; then compound 3; then compound 1. At a limit, below all of these: compound 2.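

The earlier steps shown here altered only the acyl carbon, whereas this one places a group on an aromatic carbon of the phenyl ring, para to a large group, and in this assay there is a 3.2-fold lower number from compound 3 to compound 4 (0.51 log units; beyond the scatter). Substitution on the ring alone therefore moves the number beyond the scatter. No available evidence bears on the reason for this drop.

From the compounds shown here alone, whether an amine or a carboxylic acid on the same aromatic carbon would move the number in the same direction remains open. Also open, going by these compounds, is whether the six-membered aromatic ring with 3 hetero atoms is needed for the drop.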